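The source may report more compounds than this note shows. Statements on the series, on what has been measured and on what is new or still open speak of the compounds shown alone.

Measured compounds:
Compound 1, `Clc1cc(Cl)cc(CO[C@H]2CCCN(Cc3ncco3)[C@H]2c2ccccc2)c1`: > 200000 nM
Compound 2, `CN1CCC[C@H](OCc2cc(Cl)cc(Cl)c2)[C@@H]1c1ccccc1`: > 200000 nM
Compound 3, `Clc1cc(Cl)cc(CO[C@H]2CCCN(Cc3cccnc3)[C@H]2c2ccccc2)c1`: 112000 nM

In an assay on isolated protein for activation of cGMP-dependent protein kinase 1 (Homo sapiens), read by ADP-Glo, with stated times of 120 min and 40 min (a higher number here means that more compound is needed for the effect, a lower number that less compound is needed), compound 1 gives > 200000 nM, which is a limit of the assay and not a number. Compound 2 likewise gives > 200000 nM, again a limit. Within the data shown here, compound 3 gives 112000 nM, the only real number among the three. The two other values are limits, as the limit of > 200000 nM in this assay, at which 2 of the 3 values shown sit, states. Because of that, the step that the two limits leave unreadable from compound 1 to compound 2 cannot be read, while an at least 1.7-fold lower number from compound 1 to compound 3 (0.25 log units; that floor lies within the scatter) and an at least 1.7-fold lower number from compound 2 to compound 3 (0.25 log units; that floor lies within the scatter) have floors that lie within the usual scatter.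

Compound 4, `O=C(O)c1ccc(CN2CCC[C@H](OCc3cc(Cl)cc(Cl)c3)[C@@H]2c2ccccc2)cn1`, differs from compound 3 in one place: carboxy in place of hydrogen on an aromatic carbon. Among the measured compounds shown here, none of the measured steps touches this part of the molecule; they all concern the group on the saturated chain carbon bound to the ring amine nitrogen, and they give no size that could be carried over. The expectation is therefore a step of a 1.1-fold lower number from compound 3 to compound 4 (0.05 log units; within the scatter), nothing beyond the scatter. Compound 4 is estimated at 100000 nM, with a range from 30000 nM to 300000 nM.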

Compound 4, half-maximal effective concentration: > 200000 nM
Compound 4 gave a limit, no number (the forecaster's own chance of this, stated with the estimate: 35%); middle value at least 2.0-fold (0.30 log units) from the limit.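

The earlier steps shown here all swap the group on the chain carbon, whereas this change adds carboxy to an aromatic carbon of the pyridin-3-yl group, next to the ring nitrogen, and in this assay the result is an at least 1.7-fold higher number from compound 3 to compound 4 (0.25 log units; that floor lies within the scatter). Going by these compounds, compound 4 gives > 200000 nM, which is a limit and not a number, so carboxy at this position brings no lower number, though the true size of the step stays unknown. The steps from compound 1 and from compound 2 to compound 4 cannot be read, and the one above is only a floor, because of this: the limit of > 200000 nM in this assay, at which 3 of the 4 values shown sit.

Open, on these data alone, is whether a methyl group, an amine or an amide on the same aromatic carbon would give a readable number. Also open, as far as these compounds go, is how carboxy would behave on another carbon of that ring.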